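Ether-linked aryl variation in the pyridyl amide series

The source may report more compounds than this note shows. Statements on the series, on what has been measured and on what is new or still open speak of the compounds shown alone.

Compound 1 `O=C(Nc1cccnc1)c1ccccc1OCc1ccccc1Cl` gives 1100 nM in an assay on lysate for inhibition of phosphatidylcholine:ceramide cholinephosphotransferase 2 (Homo sapiens), read by HPLC, with stated times of 30 min and 2 h (on this read-out lower numbers stand for stronger inhibition and higher numbers for weaker inhibition), the second highest of the three numbers measured. Compound 2 `O=C(Nc1cccnc1)c1ccccc1OCc1cccc(Cl)c1` gives 1400 nM and compound 3 `Cc1ccc(F)cc1COc1ccccc1C(=O)Nc1cccnc1` gives 740 nM in this assay. The steps among them, a 1.3-fold higher number from compound 1 to compound 2 (0.10 log units; within the scatter), a 1.5-fold lower number from compound 1 to compound 3 (0.17 log units; within the scatter) and a 1.9-fold lower number from compound 2 to compound 3 (0.28 log units; within the scatter), all stay within the scatter. Compound 4 `O=C(Nc1cccnc1)c1ccccc1OCc1ccccc1OCCCCCCCl` differs from compound 1 by (6-chlorohexyl)oxy in place of chloro on an aromatic carbon. For the measured compounds named here, none of the measured steps touches this position; all three swap the substitution pattern of the ring on the saturated chain carbon and move the number little. For compound 4 no step beyond the scatter is therefore expected, and the estimate is 1100 nM with a range from 300 nM to 4000 nM. The expected step for compound 4, no change at the digits printed from compound 1 to compound 4 (within the scatter), is provisional, since no measured change resembles this one.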

Compound 4, half-maximal inhibitory concentration: 470 nM
Estimate against measurement, compound 4: 2.3-fold (0.37 log units) above; the measured number falls inside the stated range.
By their numbers in this assay, from the lowest: compounds 4, 3, 1 and 2 (each within the scatter of the next, the first and the last beyond it).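

In this assay, the aromatic carbon ortho to a large group accepts a much larger substituent than chloro: (6-chlorohexyl)oxy gives a 2.3-fold lower number from compound 1 to compound 4 (0.37 log units; beyond the scatter) and is the only step shown that lies beyond the scatter. The aryl ring therefore carries a long chain here without loss of inhibition, and this position responds more than the ring-pattern swaps did. No measured evidence on the origin of this step is at hand. Open, as far as these compounds go, is whether the chain length, the ether oxygen or the terminal chlorine carries the step. A methoxy group, an unchlorinated hexyloxy chain or a terminal amine at this position would separate these.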